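A few compounds are considered here, and "the series" means these few. Any claim that something is new, unique, unknown or untested is made for them only; others in the source may bear on it.

In a physicochemical assay for lipophilicity, at pH 7.4 (on this read-out higher numbers stand for higher lipophilicity and lower numbers for lower lipophilicity), the measured compounds give these numbers:
- compound 1 `Cc1nc(C)c(-c2nnc(-c3ccc(OC(C)C)c(Cl)c3)s2)s1` (7.76)
- compound 2 `CC(C)Oc1ccc(-c2nnc(-c3ccno3)s2)cc1Cl` (6.93)

Of these two numbers, compound 2 stands lowest (6.93), and compound 1 gives 7.76. The gap between the two lies beyond the scatter. The next structure is compound 3 `CC(C)Oc1ccc(-c2nnc(-c3ccnn3C)s2)cc1Cl`, which carries 1-methyl-1H-pyrazol-5-yl in place of 1,2-oxazol-5-yl on an aromatic carbon. Within the data shown here, only one measured step bears on this change, at the same place on the shared core: a number 0.83 log units lower from compound 1 to compound 2 (beyond the scatter), modest and beyond the scatter, with 1,2-oxazol-5-yl in place of 2,4-dimethyl-1,3-thiazol-5-yl. Among the measured compounds shown here, no measured step joins this exact pair of groups, so the expectation rests on that single step. Like the group in compound 1 (7.76), the entering group bears methyl, so a small move back toward that number is expected. The expected change is a number 0.17 log units higher from compound 2 to compound 3 (within the scatter), smaller than the measured step and possibly within the scatter. For compound 3 the estimated value is 7.1, with an expected range from 6.6 to 7.6.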

Compound 3, distribution coefficient: 7.04
The estimate for compound 3 lay 0.06 log units above the measured number; measured number inside the range.
By their numbers in this assay, from the lowest: compounds 2 and 3 (each within the scatter of the next); then compound 1.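

In this assay, placing 1-methyl-1H-pyrazol-5-yl instead of 1,2-oxazol-5-yl on this aromatic carbon gives a number 0.11 log units higher from compound 2 to compound 3 (within the scatter), so this measurement does not separate these two five-membered aromatic rings, each with 2 hetero atoms. The second new step, a number 0.72 log units lower from compound 1 to compound 3 (beyond the scatter), lies beyond the scatter, as does a number 0.83 log units lower from compound 1 to compound 2 (beyond the scatter); the methyl on the entering group therefore does not bring compound 3 within the scatter of compound 1, and the 2,4-dimethyl-1,3-thiazol-5-yl group of compound 1 now stands apart from both other groups at this position. No measurement at hand offers an explanation for these numbers.

The compounds shown leave open whether the gap to compound 1 goes with the 1,3-thiazol-5-yl ring itself or with its two methyl groups, a question that a plain 1,3-thiazol-5-yl group at this position would address. Also open, on these data alone, is where a group of a different kind on this aromatic carbon, such as an amine or a carboxylic acid, would fall in this assay.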